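This account rests on a few compounds, and the source may have more. Where it says the series, first, only, none or still open, it means among the compounds named here.

Working notes on the series. All compounds share one core and differ only in the aryl group on the double-bonded chain. Compound 1 `CCCc1cc(N)c2cc(NC(=O)/C=C/c3ccccc3Cl)ccc2n1` carries 2-chlorophenyl, compound 2 `CCCc1cc(N)c2cc(NC(=O)/C=C/c3ccc(I)cc3)ccc2n1` carries 4-iodophenyl, compound 3 `CCCc1cc(N)c2cc(NC(=O)/C=C/c3ccc(Cl)c(Cl)c3)ccc2n1` carries 3,4-dichlorophenyl. In a functional assay on HEK293 cells for activation of melanin-concentrating hormone receptor 1 (Homo sapiens), read by inositol phosphate accumulation (on this read-out lower numbers stand for an effect already at smaller amounts and higher numbers for an effect only at larger amounts of compound), compound 1 gives 500 nM. Compound 2 gives 280 nM. Compound 3 gives 990 nM and so stands at the highest number of the three: the step of a 2.0-fold higher number from compound 1 to compound 3 (0.30 log units; within the scatter) stays within the scatter, whereas the step of a 3.5-fold higher number from compound 2 to compound 3 (0.55 log units; beyond the scatter) lies beyond it. The step of a 1.8-fold lower number from compound 1 to compound 2 (0.25 log units; within the scatter) is within the scatter.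

Compound 4 `CCCc1cc(N)c2cc(NC(=O)/C=C/c3ccc(Cl)cc3)ccc2n1` is the next member; relative to compound 3 the change is hydrogen in place of chloro on an aromatic carbon. Among the measured compounds shown here, the step that bears on this is the one from compound 2 to compound 3, where a para-halogen-only aryl was replaced by the dichloro pattern and the number rose beyond the scatter; compound 4 returns to a single para-halogen, so the expectation is that the number falls again, roughly toward compound 2, with the step of a 2.8-fold lower number from compound 3 to compound 4 (0.45 log units; beyond the scatter) expected. For compound 4 the estimate is 350 nM, with a range from 150 nM to 800 nM.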

Compound 4, half-maximal effective concentration: 96 nM
Compound 4: the middle estimate sits 3.6-fold (0.56 log units) above what was measured, outside the stated range (below it).
By their numbers in this assay, from the lowest: compound 4; then compounds 2, 1 and 3 (each within the scatter of the next, the first and the last beyond it).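

In this assay, among the compounds shown here, removing one chloro from the 3,4-dichlorophenyl group gives the largest step so far (a 10-fold lower number from compound 3 to compound 4 (1.01 log units; beyond the scatter)), so this aromatic carbon tolerates hydrogen far better than chloro when the ring keeps its other chloro. For the compounds shown here, the halogen also matters: chloro in place of iodo gives a step beyond the scatter (a 2.9-fold lower number from compound 2 to compound 4 (0.46 log units; beyond the scatter)), which the earlier compounds could not show. Where the single chloro sits matters too, as 4-chlorophenyl in place of 2-chlorophenyl shows (a 5.2-fold lower number from compound 1 to compound 4 (0.72 log units; beyond the scatter)), leaving compound 4 with the lowest number of the four.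

Open, going by these compounds, is whether the remaining chloro is itself needed, or whether fluoro, methyl, methoxy or hydrogen could take its place. Nothing available explains the size of these steps.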